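This account rests on a few compounds, and the source may have more. Where it says the series, first, only, none or still open, it means among the compounds named here.

Measured in a functional assay on MCF7 cells (Homo sapiens) (a lower number here means a stronger inhibitor of growth, a higher number a weaker inhibitor of growth), so far:

Compound 1 `O=S(=O)(/C=C/c1ccc(Br)cc1)Cc1ccc(Nc2ncnc3ccccc23)cc1` gives 91000 nM
Compound 2 `O=S(=O)(/C=C/c1ccc(Cl)cc1Cl)Cc1ccc(Nc2ncnc3ccccc23)cc1` gives 4000 nM
Compound 3 `COc1cc2ncnc(Nc3ccc(CS(=O)(=O)/C=C/c4ccc(Cl)cc4Cl)cc3)c2cc1OC` gives 11000 nM

Compound 3, at 11000 nM, holds the second highest of these three numbers. It is a weaker growth inhibitor than compound 2 and a stronger one than compound 1, and both gaps lie beyond the usual scatter.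

Compound 4 `COc1cc2ncnc(Nc3ccc(CS(=O)(=O)/C=C/c4ccc(F)cc4)cc3)c2cc1OC` has not yet been measured. It keeps the core of compound 3 and changes one group, on a double-bonded chain carbon bound to a double-bonded chain carbon: 4-fluorophenyl in place of 2,4-dichlorophenyl on a double-bonded chain carbon bound to a double-bonded chain carbon.

Going by the values given here, only one measured step bears on this change. Putting 2,4-dichlorophenyl in place of 4-bromophenyl gave a 23-fold lower number from compound 1 to compound 2 (1.36 log units; beyond the scatter), which is a large drop. Among the compounds with values here, that step belongs to a different core and involves bromine rather than fluorine, and no measured compound carries 4-fluorophenyl, so it is only a rough guide.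

The new change runs the opposite way, from 2,4-dichlorophenyl to a phenyl with one halogen. A higher number is therefore expected in this assay, probably by less than that earlier step but still beyond the scatter. Compound 4 is expected at about 40000 nM, with an estimated range from 11000 nM to 150000 nM. The estimate amounts to a 3.6-fold higher number from compound 3 to compound 4 (0.56 log units; beyond the scatter).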

Compound 4, concentration for 50% growth inhibition: > 100000 nM
Compound 4: only a limit was reported; the forecaster's own chance of this, stated with the estimate: 10%; at least 2.5-fold (0.39 log units) between middle value and limit.
By their numbers in this assay, from the lowest: compound 2; then compound 3; then compound 1. At a limit, above all of these: compound 4.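

In this assay, the group on the double-bonded chain carbon now proves to matter on a second core as well: the change to 4-fluorophenyl gives an at least 9.0-fold higher number from compound 3 to compound 4 (0.95 log units; beyond the scatter). Compound 4 gives a limit and not a number: the limit of > 100000 nM in this assay, at which 1 of the 4 values shown sits. Until now the only step at this place was a 23-fold lower number from compound 1 to compound 2 (1.36 log units; beyond the scatter), on a different core and with 4-bromophenyl as the partner, so the two steps together put 2,4-dichlorophenyl on the lower number in both pairs, and no compound shown goes against this.

The compounds shown leave open whether both chlorines are needed for this difference, since a 4-chlorophenyl or a 2-chlorophenyl group in the same place would separate the two, and whether 4-fluorophenyl and 4-bromophenyl differ from each other on a single core. As far as these compounds go, it also remains open how a phenyl ring carrying no halogen at all, such as one bearing a methoxy group or an amine, would compare with 2,4-dichlorophenyl in this position.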